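Thiosemicarbazones on a monoterpene alcohol scaffold: cytotoxicity notes

The source may hold more compounds than are shown below. What is called first, only, known or untested is meant among the compounds shown, and "the series" means these compounds.

Measured compounds:
Compound 1, `CC1=CC[C@@H]([C@@](C)(O)CCCC(C)(C)NC=S)CC1`. In a functional assay on K562 cells (Homo sapiens) for cytotoxicity, read by sulforhodamine B assay (on this read-out lower numbers stand for higher toxicity in this test and higher numbers for lower toxicity in this test), compound 1 gives > 100000 nM, which is a limit of the assay and not a number.
Compound 2, `COc1ccc(/C=N\NC(=S)NC(C)(C)CCC[C@](C)(O)[C@@H]2CC=C(C)CC2)cc1`. In this assay compound 2 gives > 100000 nM, again a limit.
Compound 3, `CC1=CC[C@@H]([C@@](C)(O)CCCC(C)(C)NC(=S)N/N=C\c2ccc(N(C)C)cc2)CC1`. In this assay compound 3 gives > 100000 nM, also a limit.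

Going by the values given here, compound 3 thus stands at the limit, as do the two other values shown; no compound of the series has a measured number. Among the compounds with values here, the one step between compounds differing in one place, a step that the two limits leave unreadable from compound 2 to compound 3, is left unreadable by the two limits. Within the data shown here, the only evidence on the measured steps is the limit of > 100000 nM in this assay, at which 3 of the 3 values shown sit.

Compound 4, `CC1=CC[C@@H]([C@@](C)(O)CCCC(C)(C)NC(=S)N/N=C\c2ccccc2Cl)CC1`, differs from compound 3 by 2-chlorophenyl in place of 4-(dimethylamino)phenyl on a carbon with a double bond to nitrogen. Among the measured compounds shown here, no measured step bears on this change: the single step available is unreadable, and every value shown sits at the limit, so neither direction nor size can be read from the series. Given that, compound 4 is expected to give 100000 nM, with a range from 30000 nM to 300000 nM. The step expected here, a number no higher from compound 3 to compound 4 (the limit leaves the size open), is none beyond the scatter, and the most likely outcome is that compound 4 again returns only a limit.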

Compound 4, concentration lethal to 50% of the cells: 8500 nM
Compound 4: middle estimate off by 12-fold (1.07 log units), on the high side, outside the stated range (below it).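

Going by these compounds alone, at the carbon with a double bond to nitrogen, the aryl group can move the read-out in this assay, which the earlier compounds, all at the limit, could not show. 2-Chlorophenyl in place of 4-(dimethylamino)phenyl gives an at least 11-fold lower number from compound 3 to compound 4 (1.07 log units; beyond the scatter), and 2-chlorophenyl in place of 4-methoxyphenyl gives an at least 11-fold lower number from compound 2 to compound 4 (1.07 log units; beyond the scatter). Both steps start from a limit, so each size is only a minimum: the limit of > 100000 nM in this assay, at which 3 of the 4 values shown sit.

Going by these compounds, how a plain phenyl or a bromophenyl group would read at this carbon stays open, and with it whether the chlorine itself accounts for the steps. Also open, on these data alone, is whether a change to the tertiary alcohol of the shared core, such as a methyl ether, would alter the number of compound 4.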